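From Compound 2 to Compound 4: Changing the Aryl Group

The compounds below may be only part of what the source reports. "The series", "measured", "known", "first", "only" and "open" are said of these compounds alone.

All numbers here come from a functional assay on SW-620 cells (Homo sapiens) for antiproliferative activity, read by MTT assay, with a stated time of 72 h; a lower number here means a stronger inhibitor, a higher number a weaker inhibitor.

Compound 1 `CC(C)(C)c1cn(C[C@H](O)[C@H]2OC(=O)C(OCc3ccccc3)=C2OCc2ccccc2)nn1`: 35800 nM
Compound 2 `O=C1O/C(=C\Cn2cc(-c3cc(F)cc(F)c3)nn2)C(OCc2ccccc2)=C1OCc1ccccc1`: a limit, > 100000 nM
Compound 3 `O=C1O[C@H]([C@@H](O)Cn2cc(-c3cc(F)cc(F)c3)nn2)C(OCc2ccccc2)=C1OCc1ccccc1`: a limit, > 100000 nM.

The value of compound 2 is a limit of the assay rather than a number. The same holds for compound 3, whose value is likewise a limit. Among the measured compounds shown here, compound 1 is the only compound of the three with a measured number, and the step of an at least 2.7-fold higher number from compound 1 to compound 3 (0.44 log units; beyond the scatter) runs from that number up to a limit. Two of the three values sit at one and the same limit (the limit of > 100000 nM in this assay, at which 2 of the 3 values shown sit).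

Compound 4 `O=C1O/C(=C\Cn2cc(-c3ccc(Br)cc3)nn2)C(OCc2ccccc2)=C1OCc1ccccc1` has not yet been measured. It differs from compound 2 in a single place: 4-bromophenyl in place of 3,5-difluorophenyl on an aromatic carbon. For the measured compounds named here, the only measured step, an at least 2.7-fold higher number from compound 1 to compound 3 (0.44 log units; beyond the scatter), replaces tert-butyl with 3,5-difluorophenyl and so exchanges no aryl group for another aryl group; it gives no direct guide to the size or direction of the change considered here. Compound 2 itself stands at the limit, so there is no number from which a step could be read off. The expectation for compound 4 is therefore a value again at or near the limit, with no step beyond the scatter expected, a number no higher from compound 2 to compound 4 (the limit leaves the size open). The estimate for compound 4 is 100000 nM, within 30000 nM to 300000 nM.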

Compound 4, half-maximal inhibitory concentration: > 100000 nM
Compound 4: only a limit was reported; the forecaster's own chance of this, stated with the estimate: 70%; the middle value lies on the limit itself.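

Compound 4 and compound 2 both stand at a limit of the assay rather than at a number, so no step can be read between them: the limit of > 100000 nM in this assay, at which 3 of the 4 values shown sit. The compounds shown leave open whether 4-bromophenyl and 3,5-difluorophenyl differ at all in this assay on the shared core.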